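A few compounds are considered here, and "the series" means these few. Any claim that something is new, unique, unknown or untested is made for them only; others in the source may bear on it.

In a functional assay on HCT-116 cells (Homo sapiens) (a higher number here means a weaker inhibitor, a lower number a stronger inhibitor), compound 1 (`COc1cc(NC(C)CCCNC(=O)NCCCO)c2ncccc2c1`) gives > 100000 nM, which is a limit of the assay and not a number. Compound 2 (`COc1cc(NC(C)CCCNC(=O)NC(CO)(CO)CO)c2ncccc2c1`) gives > 100000 nM, which is likewise a limit and not a number. Compound 2 therefore has no exact position, and the evidence so far is the limit of > 100000 nM in this assay, at which 2 of the 2 values shown sit.

Compound 3 (`COc1cc(NC(C)CCCNC(=O)NO)c2ncccc2c1`) keeps the shared core and changes one group: hydroxy in place of 2-hydroxy-1,1-bis(hydroxymethyl)ethyl on an amide-type nitrogen, (hydroxy in place of 2-hydroxy-1,1-bis(hydroxymethyl)ethyl on an amide-type nitrogen).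

Among the measured compounds shown here, only one measured step bears on this, since it concerns the same nitrogen: a step that the two limits leave unreadable from compound 1 to compound 2. It offers no size to carry over. Its two ends do show that neither group brought a value into the readable range, so compound 3 is expected to remain a weak inhibitor. The present change is a different one, however, so a modest move towards stronger inhibition is allowed for, and the expected size is an at least 2.0-fold lower number from compound 2 to compound 3 (0.30 log units; that floor lies within the scatter). The estimate for compound 3 is 50000 nM, with an expected range from 10000 nM to 100000 nM.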

Compound 3, half-maximal inhibitory concentration: 57000 nM
Compound 3: middle estimate off by 1.1-fold (0.06 log units), on the low side; the measured number falls inside the stated range.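

Compound 3 is the only compound shown with a real number in this assay (57000 nM), so a group on this amide-type nitrogen can bring a value into the readable range. Hydroxy in place of 2-hydroxy-1,1-bis(hydroxymethyl)ethyl gives an at least 1.7-fold lower number from compound 2 to compound 3 (0.24 log units; that floor lies within the scatter) and hydroxy in place of 3-hydroxypropyl gives an at least 1.7-fold lower number from compound 1 to compound 3 (0.24 log units; that floor lies within the scatter), and each of these is only a floor that lies within the scatter, so the true steps could be larger or could be too small to count as real, while the step between compound 1 and compound 2 cannot be read. Compound 1 and compound 2 give no number of their own, only a limit of the assay: the limit of > 100000 nM in this assay, at which 2 of the 3 values shown sit.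

As far as these compounds go, how far compound 1 and compound 2 really lie from compound 3 stays unknown, and so does whether the change matters through the hydroxy itself or simply through the loss of the larger carbon groups. A methoxy group, a plain methyl group or an amine on the same nitrogen would be needed to tell these readings apart.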